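The source may report more compounds than this note shows. Statements on the series, on what has been measured and on what is new or still open speak of the compounds shown alone.

Of the compounds shown here, two have been tested so far in a functional assay on HTB-54 cells (Homo sapiens) for cytotoxicity, read by MTT assay, with a stated time of 72 h; on this read-out lower numbers stand for stronger inhibition of growth and higher numbers for weaker inhibition of growth. Compound 1, `COc1ccc(CNc2nc(SC)nc3ncccc23)cc1`, gives only a limit of the assay, > 100000 nM. Among the measured compounds shown here, compound 2, `CSc1nc(NCc2ccccc2)c2cccnc2n1`, gives 51600 nM, the single true number among the results. For the measured compounds named here, the one measured step, an at least 1.9-fold lower number from compound 1 to compound 2 (0.28 log units; that floor lies within the scatter), is itself bounded by a limit, as the limit of > 100000 nM in this assay, at which 1 of the 2 values shown sits, shows, so even its size is known only as a floor.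

Compound 3, `CSc1nc(NCCCCCO)c2cccnc2n1`, has not been measured. It differs from compound 2 in one place: 4-hydroxybutyl in place of phenyl on a saturated chain carbon bound to a nitrogen on an aromatic ring. Going by the values given here, no measured step covers this kind of change; the one step on record concerns a methoxy on an aromatic carbon, not the group on the saturated chain carbon bound to a nitrogen on an aromatic ring. Among the compounds with values here, the data therefore point in no direction for this step, and the expectation is simply that compound 3 stays close to compound 2, with a wide range to reflect the absence of guidance. The expected change is a 1.4-fold higher number from compound 2 to compound 3 (0.13 log units; within the scatter). For compound 3 the estimate in this assay is 70000 nM, between 25000 nM and 200000 nM.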

Compound 3, concentration for total growth inhibition: > 100000 nM
Compound 3: a limit, no number; the forecaster's own chance of this, stated with the estimate: 40%; middle value at least 1.4-fold (0.15 log units) away from the limit.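

The step from the phenyl of compound 2 to the 4-hydroxybutyl of compound 3 is the only one shown at this place, on a saturated chain carbon bound to a nitrogen on an aromatic ring, whereas the earlier step concerned a methoxy on an aromatic carbon. In this assay this change gives an at least 1.9-fold higher number from compound 2 to compound 3 (0.28 log units; that floor lies within the scatter), so it does not lower the number, although the floor alone cannot establish a real loss of growth inhibition. The true size of the step stays unknown because the reading of compound 3 is a limit, not a number: the limit of > 100000 nM in this assay, at which 2 of the 3 values shown sit.

This one change removes a carbon-only aromatic ring and brings in a chain ending in a hydroxyl group, so the compounds shown cannot tell which of the two matters, and a plain butyl group in the same place would help to separate them. As far as these compounds go, it also remains open how an amine or a carboxylic acid at the end of the chain, or a chlorine on the phenyl ring of compound 2, would read in this assay.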